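Methyl on the Amine Nitrogen: From Compound 1 to Compound 4

The source may hold more compounds than are shown below. What is called first, only, known or untested is meant among the compounds shown, and "the series" means these compounds.

Three amides built on a shared core were tested in a functional assay on MDA-MB-435 cells (Homo sapiens) for cytotoxicity, read by MTT assay, with a stated time of 72 h; on this read-out lower numbers stand for stronger inhibition and higher numbers for weaker inhibition. Compound 1 `NCCCNc1c(C(=O)NCc2ccc(F)cc2)nc(Br)c2cccnc12` gives 5000 nM, the highest of the three numbers. Compound 2 `N[C@H]1CC[C@H](Nc2c(C(=O)NCc3ccc(Oc4ccccc4)cc3)nc(Br)c3cccnc23)CC1` gives 4000 nM, within the scatter of compound 1, while compound 3 `N[C@H]1CC[C@H](Nc2c(C(=O)NCc3ccc(Cl)cc3)nc(Br)c3cccnc23)CC1` gives 1000 nM. Within the data shown here, the only single-point step among them is a 4.0-fold lower number from compound 2 to compound 3 (0.60 log units; beyond the scatter), a change on an aromatic carbon. Compound 4 `CNCCCNc1c(C(=O)NCc2ccc(F)cc2)nc(Br)c2cccnc12` differs from compound 1 by methyl in place of hydrogen on an amine nitrogen. Among the measured compounds shown here, no measured step touches an amine nitrogen, so this change has no precedent in the data, and no step beyond the scatter is expected. Compound 4 is therefore estimated at 5000 nM, with a range of 2000 nM to 12000 nM, an expected step of no change at the digits printed from compound 1 to compound 4 (within the scatter).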

Compound 4, half-maximal inhibitory concentration: 11000 nM
Beside the measured number, compound 4's estimate is 2.2-fold (0.34 log units) below it; low and high end bracket the measured number.
By their numbers in this assay, from the lowest: compound 3; then compounds 2 and 1 (each within the scatter of the next); then compound 4.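

In this assay methyl in place of hydrogen on the amine nitrogen gives a 2.2-fold higher number from compound 1 to compound 4 (0.34 log units; beyond the scatter) and so points toward weaker inhibition. Among these compounds, this is the first sign in these compounds that the amine nitrogen of the chain responds to change, even to a single added carbon. Nothing measured here explains the step. Still open, as far as these compounds go, is whether a larger group on this nitrogen, such as ethyl or acetyl, would raise the number further, and whether methyl would give a similar step on the amine of compound 3.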